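Triazole substituent swap on a flavanone core: cyclopentyl to 2-methylbenzyl

The compounds below may be only part of what the source reports. "The series", "measured", "known", "first", "only" and "open" are said of these compounds alone.

Measured compounds:
compound 1 `COc1ccc([C@@H]2CC(=O)c3c(O)cc(OCc4cn(C5CCCC5)nn4)cc3O2)cc1O`, 10500 nM
compound 2 `COc1ccc([C@@H]2C/C(=N\O)c3c(O)cc(OCc4cn(Cc5ccccc5F)nn4)cc3O2)cc1O`, 5710 nM
compound 3 `CCCn1cc(COc2cc(O)c3c(c2)O[C@H](c2ccc(OC)c(O)c2)C/C3=N\O)nn1`, 2340 nM

In a functional assay on RAW264.7 cells (Mus musculus) for inhibition, read by Griess assay, with stated times of 2 h and 24 h (a lower number here means a stronger inhibitor, a higher number a weaker inhibitor), compound 1 gives the highest number of the three, though its gap to compound 2 is within the scatter, and compound 3 sits furthest below it. Compound 4 `COc1ccc([C@@H]2CC(=O)c3c(O)cc(OCc4cn(Cc5ccccc5C)nn4)cc3O2)cc1O` differs from compound 1 by 2-methylbenzyl in place of cyclopentyl on an aromatic nitrogen. For the measured compounds named here, no measured step covers this exact exchange. Going by the values given here, the only related comparison, a 2.4-fold lower number from compound 2 to compound 3 (0.39 log units; beyond the scatter), shows a modest shift on a different core, where a smaller chain gave the lower number; it offers little direct guidance. The step of a 1.2-fold lower number from compound 1 to compound 4 (0.07 log units; within the scatter) is therefore expected to be small, with no change beyond the scatter. Compound 4 is estimated at 9000 nM, within a range from 3500 nM to 25000 nM.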

Compound 4, half-maximal inhibitory concentration: 13100 nM
Estimate against measurement, compound 4: 1.5-fold (0.16 log units) below; the range from low to high includes it.
By their numbers in this assay, from the lowest: compound 3; then compounds 2, 1 and 4 (each within the scatter of the next, the first and the last beyond it).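

In this assay putting 2-methylbenzyl in place of cyclopentyl on an aromatic nitrogen gives a 1.2-fold higher number from compound 1 to compound 4 (0.10 log units; within the scatter). On the core of compound 1, this position therefore takes either a non-aromatic carbon ring or a larger group bearing an aromatic carbon ring, with no change beyond the scatter. No available evidence bears on this result.

Going by these compounds, whether an amine or a carboxylic acid at this nitrogen would shift the number remains open. So does whether the chain of compound 3 would give a lower number on the core of compound 1.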